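Adding a second ring methyl to compound 3

The source may hold more compounds than are shown below. What is called first, only, known or untested is meant among the compounds shown, and "the series" means these compounds.

Three compounds share one core and differ only in what sits on an amide-type nitrogen in a ring. Compound 1 `CC(C)[C@@H]1CC[C@@H](C)C[C@@]12N(C)C(=O)[C@@H]1[C@H]3C(=O)NC(=O)[C@H]3ON12` carries hydrogen there and in a functional assay, with a stated time of 20 min, tested at 1 mg/mL (on this read-out higher numbers stand for a stronger effect at the one concentration tested and lower numbers for a weaker effect), compound 1 gives 39.3%. Compound 2 `CC(C)[C@@H]1CC[C@@H](C)C[C@@]12N(C)C(=O)[C@@H]1[C@H]3C(=O)N(c4ccccc4)C(=O)[C@H]3ON12` carries phenyl and in this assay compound 2 gives 54.9%. Compound 3 `Cc1cccc(N2C(=O)[C@H]3[C@H](ON4[C@@H]3C(=O)N(C)[C@@]43C[C@H](C)CC[C@H]3C(C)C)C2=O)c1` carries 3-methylphenyl and in this assay compound 3 gives 38.7%, the lowest of the three numbers, though compound 1 is within the scatter of it and only compound 2 lies clearly higher.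

The measured steps show that placing phenyl on this nitrogen raised the number, a number 15.6 percentage points higher from compound 1 to compound 2 (beyond the scatter), while a methyl on an aromatic carbon took that gain away again, a number 16.2 percentage points lower from compound 2 to compound 3 (beyond the scatter), so that a number 0.6 percentage points lower from compound 1 to compound 3 (within the scatter).

Compound 4 `Cc1ccc(N2C(=O)[C@H]3[C@H](ON4[C@@H]3C(=O)N(C)[C@@]43C[C@H](C)CC[C@H]3C(C)C)C2=O)c(C)c1` goes one step further: 2,4-dimethylphenyl in place of 3-methylphenyl on an amide-type nitrogen in a ring. Among the measured compounds shown here, the only step that bears on it is the one from compound 2 to compound 3, where a methyl on the aromatic ring lowered the number modestly. A second methyl is therefore expected to hold the number down or lower it a little, a number 5.7 percentage points lower from compound 3 to compound 4 (within the scatter), with no clear prospect of recovering the level of compound 2. For compound 4 the expected value in this assay is 33%, between 20% and 48%.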

Compound 4, a percentage reported as activity, at one concentration (the size of the read-out at that concentration, not a potency): 57%
Estimate against measurement, compound 4: 24 percentage points below, outside the stated range (above it).
By their numbers in this assay, from the lowest: compounds 3 and 1 (each within the scatter of the next); then compounds 2 and 4 (each within the scatter of the next).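

Methyl groups on this phenyl ring do not act in one fixed direction: 2,4-dimethylphenyl in place of 3-methylphenyl gives a number 18.3 percentage points higher from compound 3 to compound 4 (beyond the scatter) in this assay and so reverses the earlier drop. Against plain phenyl, the new group gives a number 2.1 percentage points higher from compound 2 to compound 4 (within the scatter) and the two cannot be told apart, while against hydrogen it gives a number 17.7 percentage points higher from compound 1 to compound 4 (beyond the scatter) on this nitrogen. Nothing available explains why these two methylphenyl groups part ways.

This step changes both the number of methyls and where they sit, so the compounds shown cannot say which of the two matters. As far as these compounds go, how the number would respond to an amine or a carboxylic acid on the phenyl ring, or to a longer chain such as ethyl in place of methyl, also remains open.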